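The source may hold more compounds than are shown below. What is called first, only, known or untested is meant among the compounds shown, and "the series" means these compounds.

Working notes on the series. In a functional assay on U-937 cells (Homo sapiens) for inhibition, read by MTT assay, with a stated time of 24 h (on this read-out higher numbers stand for weaker inhibition of growth and lower numbers for stronger inhibition of growth), compound 2 `COc1ccc(Cn2ncc3c2NC(=O)CC(c2cccc(NC(=O)Nc4cccc(Cl)c4)c2)=N3)cc1` gives 630 nM. Compound 1 `O=C1CC(c2cccc(NC(=O)c3ccc(Cl)c(C(F)(F)F)c3)c2)=Nc2cnn(Cc3ccccc3)c2N1` gives 60 nM, so compound 2 holds the higher of the two true numbers, and the gap between them lies beyond the scatter. For compound 3 `O=C1CC(c2cccc(NC(=O)Nc3ccc(Cl)cc3)c2)=Nc2cn[nH]c2N1`, the result is only a limit, > 30000 nM.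

The next compound to be read is compound 4 `COc1ccc(Cn2ncc3c2NC(=O)CC(c2cccc(NC(=O)Nc4cc(Cl)cc(Cl)c4)c2)=N3)cc1`, which is compound 2 with one further substituent on the urea's outer aryl ring. This is chloro in place of hydrogen on an aromatic carbon. In other words, chloro takes the place of hydrogen on an aromatic carbon, and 3-chlorophenyl becomes 3,5-dichlorophenyl.

Going by the values given here, no measured pair differs in one place only, so the size of this step has no direct precedent, and the estimate is loose. Compound 1 at 60 nM shows that numbers well under that of compound 2 occur among these compounds, but it differs from compound 2 in more than one place. A small move toward stronger growth inhibition in this assay is expected, close to the edge of the scatter, and the estimated change is a 1.8-fold lower number from compound 2 to compound 4 (0.26 log units; within the scatter). For compound 4 the expected value is 350 nM, with an estimated range of 100 nM to 1200 nM.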

Compound 4, concentration for 50% growth inhibition: 6480 nM
Estimate against measurement, compound 4: 19-fold (1.27 log units) below; the measured number lies above the stated range.
By their numbers in this assay, from the lowest: compound 1; then compound 2; then compound 4. At a limit, above all of these: compound 3.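

In this assay, chloro in place of hydrogen on an aromatic carbon, meta to a chloro group and meta to a large group, gives a 10-fold higher number from compound 2 to compound 4 (1.01 log units; beyond the scatter). Going by these compounds alone, this is the first step that differs in one place only, and it shows that a single added heavy atom at this position of the outer aryl ring of the urea is enough to weaken growth inhibition sharply, so the position is not indifferent to substitution. Compound 4 still reads as a true number, and only compound 3 stands at a limit: the limit of > 30000 nM in this assay, at which 1 of the 4 values shown sits.

A single step cannot tell whether the weakening belongs to chloro specifically or to any substituent at this position, and a fluoro, a methoxy group or an amine in the same place would separate those two readings. Also open, going by these compounds, is whether the same change would weaken growth inhibition to a similar extent on the amide of compound 1, whose outer ring carries trifluoromethyl and chloro groups.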